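Sulfonyl group changes and cytotoxicity in one series

A few compounds are considered here, and "the series" means these few. Any claim that something is new, unique, unknown or untested is made for them only; others in the source may bear on it.

Compound 1 `O=S(=O)(Nc1ccc(-c2nc3ccccc3o2)cc1)c1cccs1` in an ADME assay on HEK293 cells (Homo sapiens) for cytotoxicity, read by resazurin assay, with a stated time of 48 h (on this read-out higher numbers stand for lower toxicity in this test and lower numbers for higher toxicity in this test), gives > 100000 nM, a limit of the assay.
Compound 2 `O=S(=O)(Nc1ccc(-c2nc3ccccc3o2)cc1)c1cccc(Cl)c1` in this assay gives > 100000 nM, again a limit.
Compound 3 `Cc1ccccc1S(=O)(=O)Nc1ccc(-c2nc3ccccc3o2)cc1` in this assay gives > 100000 nM, also a limit.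

Within the data shown here, compound 3 thus stands only at a limit in this assay; all three values sit at the same limit (the limit of > 100000 nM in this assay, at which 3 of the 3 values shown sit), so no compound can be set above another. Compound 4 `Cc1cccc(S(=O)(=O)Nc2ccc(-c3nc4ccccc4o3)cc2)c1` differs from compound 3 by 3-methylphenyl in place of 2-methylphenyl on a sulfonyl sulfur. The measured steps that alter the group on the sulfonyl sulfur, a step that the two limits leave unreadable from compound 1 to compound 2, a step that the two limits leave unreadable from compound 1 to compound 3 and a step that the two limits leave unreadable from compound 2 to compound 3, are all unreadable; both ends of each are limits. Nothing therefore points to a step beyond the scatter in this assay in either direction. Compound 4 is expected to give 150000 nM (range 60000 nM to 400000 nM), most likely reported again as a limit. The expected step is a step that the limit leaves unreadable from compound 3 to compound 4.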

Compound 4, half-maximal cytotoxic concentration: > 100000 nM
Compound 4 was reported as a limit; the forecaster's own chance of this, stated with the estimate: 85%; the middle value lies beyond the limit too.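

In this assay compound 4 gives > 100000 nM, again a limit. No step among compound 1, compound 2, compound 3 and compound 4 can be read: the limit of > 100000 nM in this assay, at which 4 of the 4 values shown sit.

The compounds shown leave open whether any group on the sulfonyl sulfur alters the half-maximal cytotoxic concentration in this assay.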